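Swapping a Methylpyridine for a Fluorobenzyl Group

The source may hold more compounds than are shown below. What is called first, only, known or untested is meant among the compounds shown, and "the series" means these compounds.

Of the compounds shown here, three sharing one core have been tested in a functional assay on U2OS cells with metabotropic glutamate receptor 5 (Homo sapiens) as the target, read by calcium flux; a higher number here means a larger maximal response, a lower number a smaller maximal response. Compound 1 `Fc1ccc(-c2nc(-c3ccc4c(c3)nnn4C3CCCC3)no2)cc1` gives 51%, compound 2 `CC(C)n1nnc2c1CCC(c1nc(-c3ccc(F)cc3)no1)C2` gives 98%, and compound 3 `Cc1ccc(-c2noc(C3CCc4c(nnn4C(C)(C)C)C3)n2)cn1` gives 67%. On these numbers compound 3 stands second highest of the three: compound 1 is its nearest neighbour and lies below it by more than the usual scatter, while compound 2 lies above it by a still larger margin, also beyond the scatter.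

Compound 4 `CC(C)(C)n1nnc2c1CCC(c1nc(Cc3ccc(F)cc3)no1)C2` has not yet been measured. It differs from compound 3 in one place: 4-fluorobenzyl in place of 6-methylpyridin-3-yl on an aromatic carbon. Among the compounds with values here, no two measured compounds differ in only one place, so no measured step shows the effect of this change directly. Compound 2 also carries fluorine on its outer ring and gives the highest value, 98%, but it differs from compound 4 in a second place as well, so it can only hint at the direction.

In this assay compound 4 is expected to move upward from compound 3 by a number 11 percentage points higher from compound 3 to compound 4 (beyond the scatter), a modest step near the edge of the scatter. The estimate for compound 4 is 78%, with a range from 45% to 100%.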

Compound 4, largest response reached (reported as percent of maximum), in percent of the reference or control that the assay uses: 77%
For compound 4 the middle estimate is 1 percentage points above the measured one; the measured number falls inside the stated range.
By their numbers in this assay, from the lowest: compound 1; then compounds 3 and 4 (each within the scatter of the next); then compound 2.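

Within the data shown here, this is the first measured step at this position, an aromatic carbon of the five-membered aromatic ring with 2 nitrogen and 1 oxygen, between two ring nitrogen atoms, and in this assay it reads a number 10 percentage points higher from compound 3 to compound 4 (within the scatter). The exchange removes 6-methylpyridin-3-yl, whose ring holds a nitrogen and counts as a hydrogen-bond acceptor, and brings in 4-fluorobenzyl, whose ring is carbon only and which has no hydrogen-bond acceptor, yet the two compounds cannot be told apart in maximal response, so at this position the read-out does not depend on that ring nitrogen in this pair. Nothing measured alongside these numbers offers an explanation for this result.

The compounds shown leave open how far this position accepts other kinds of group, for example a plain benzyl without the fluorine, a cyclohexyl ring with no aromatic character, or a morpholine attached through its nitrogen. Among these compounds, they also leave open whether 4-fluorobenzyl and 6-methylpyridin-3-yl would stay this close on a core carrying a different group in place of the one shared by compound 3 and compound 4.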